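The compounds below may be only part of what the source reports. "The series", "measured", "known", "first", "only" and "open" are said of these compounds alone.

In a functional assay on NB-4 cells (Homo sapiens) for inhibition, read by XTT assay, with a stated time of 48 h (a lower number here means a stronger inhibitor, a higher number a weaker inhibitor), compound 1 `CC(=O)OC/C(=C\c1ccccc1F)C(=O)c1ccccc1` gives 5800 nM and compound 2 `COc1ccc(C(=O)/C(=C/c2ccc(Cl)cc2Cl)CCOC(C)=O)cc1` gives 34800 nM, the higher of the two numbers, with a gap beyond the scatter. Compound 3 `COc1ccc(C(=O)/C(=C/c2ccc(Cl)cc2)CCOC(C)=O)cc1` departs from compound 2 in one place: hydrogen in place of chloro on an aromatic carbon, with 2,4-dichlorophenyl becoming 4-chlorophenyl. Among the measured compounds shown here, no measured pair isolates this change, so the expectation is weakly founded. The estimated 1.6-fold lower number from compound 2 to compound 3 (0.20 log units; within the scatter) is small, toward a lower number in this assay, and may well stay within the scatter. For compound 3 the expected value is 22000 nM, with an estimated range of 9000 nM to 50000 nM.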

Compound 3, half-maximal inhibitory concentration: 36300 nM
Estimate against measurement, compound 3: 1.7-fold (0.22 log units) below; the range from low to high includes it.
By their numbers in this assay, from the lowest: compound 1; then compounds 2 and 3 (each within the scatter of the next).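

In this assay, among the compounds shown here, the first pair to isolate this change gives a 1.0-fold higher number from compound 2 to compound 3 (0.02 log units; within the scatter) and so shows that, on the core of compound 2, removing the chloro group ortho to a large group leaves the read-out within the scatter. The pair gives no sign that this chloro group matters here, though that holds for this one pair only. No data on hand bear on this result.

Going by these compounds, whether an amine or a carboxylic acid at this position would also leave the read-out within the scatter remains open. On these data alone, compound 1 differs from compound 2 in more than one place, so what separates their values also remains open.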